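Hydrazide series: cytotoxicity in lung cells, nitro removal

The source may hold more compounds than are shown below. What is called first, only, known or untested is meant among the compounds shown, and "the series" means these compounds.

Measured compounds:
compound 1 `O=C(NNC(=O)c1cccc([N+](=O)[O-])c1)c1ccc(-n2cccc2)cc1` — 203000 nM
compound 2 `CC(=O)N1N=C(c2ccc(-n3c(C)ccc3C)cc2)OC1c1ccc(N(C)C)cc1` — 186000 nM

In an ADME assay on A549 cells (Homo sapiens) for cytotoxicity, read by MTT assay, with a stated time of 72 h (on this read-out higher numbers stand for weaker inhibition and lower numbers for stronger inhibition), compound 1 gives 203000 nM and compound 2 gives 186000 nM; the two values sit within the scatter of each other, so neither stands apart. Compound 3 `O=C(NNC(=O)c1ccc(-n2cccc2)cc1)c1ccccc1` is not yet measured in this assay. It differs from compound 1 as follows: hydrogen in place of nitro on an aromatic carbon. Within the data shown here, no measured pair shows the effect of such a change. Both measured compounds are weak, and a shift beyond the scatter is not expected for compound 3; the estimated step of a 1.0-fold lower number from compound 1 to compound 3 (0.01 log units; within the scatter) is therefore close to none. Compound 3 is expected at 200000 nM, within 80000 nM to 500000 nM.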

Compound 3, half-maximal inhibitory concentration: 215000 nM
Compound 3: the middle estimate sits 1.1-fold (0.03 log units) below what was measured, within the range that was stated.
By their numbers in this assay, from the lowest: compounds 2, 1 and 3 (each within the scatter of the next).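

In this assay, among these compounds, hydrogen in place of nitro on this aromatic carbon gives a 1.1-fold higher number from compound 1 to compound 3 (0.02 log units; within the scatter), the first single-place step. The nitro group can therefore leave this position with no shift beyond the scatter, and the weak cytotoxicity of compound 1 does not depend on it. No supporting measurement bears on why this change is tolerated.

Open, from the compounds shown here alone, is whether an amine or a carboxylic acid on this aromatic carbon would shift the number beyond the scatter. Also open, going by these compounds, is whether other positions on the shared core respond more strongly.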